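From chlorofluorophenyl to trifluorophenyl under a cytotoxicity limit

A few compounds are considered here, and "the series" means these few. Any claim that something is new, unique, unknown or untested is made for them only; others in the source may bear on it.

- In a functional assay on HepG2 cells (Homo sapiens) for cytotoxicity, with a stated time of 72 h (on this read-out higher numbers stand for an effect only at larger amounts of compound and lower numbers for an effect already at smaller amounts), compound 1 `C=C[C@@](C)(/C=C/c1ccc(Nc2ccccc2)cc1)CCC=C(C)C` gives > 52000 nM as a limit
- In this assay compound 2 `C=C[C@@](C)(/C=C/c1ccc(Nc2ccc(Cl)c(F)c2)cc1)CCC=C(C)C` gives > 52000 nM as a limit

Compound 2 therefore has no number, only a limit. Both measured compounds stand at the limit of > 52000 nM in this assay, at which 2 of the 2 values shown sit, and neither has a readable value. Compound 3 `C=C[C@@](C)(/C=C/c1ccc(Nc2cc(F)c(F)cc2F)cc1)CCC=C(C)C` differs from compound 2 at the group on the nitrogen: 2,4,5-trifluorophenyl in place of 4-chloro-3-fluorophenyl on a nitrogen on an aromatic ring is the whole change. Among the measured compounds shown here, the one measured step bearing on it is a step that the two limits leave unreadable from compound 1 to compound 2 and it offers no size to carry over. No step beyond the scatter is therefore expected in this assay and no direction can be given. The expected step is a step that the limit leaves unreadable from compound 2 to compound 3 on this estimate. Compound 3 is estimated at 55000 nM with an expected range of 30000 nM to 100000 nM and may well report only a limit.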

Compound 3, half-maximal effective concentration: > 52000 nM
Compound 3 ended at the assay's limit (the forecaster's own chance of this, stated with the estimate: 80%); the middle value lies beyond the limit too.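

No new step can be read among compound 1, compound 2 and compound 3, since all three report only a limit: the limit of > 52000 nM in this assay, at which 3 of the 3 values shown sit. The compounds shown leave open whether the group on the nitrogen changes the read-out in this assay at all.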